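A few compounds are considered here, and "the series" means these few. Any claim that something is new, unique, unknown or untested is made for them only; others in the source may bear on it.

Of the compounds shown here, two built on a shared core have so far been tested in a functional assay on NCI-H460 cells (Homo sapiens) for cytotoxicity, read by MTT assay, with a stated time of 72 h; on this read-out lower numbers stand for stronger inhibition and higher numbers for weaker inhibition. Compound 1 (`COc1ccc(/C=C2\CNC/C(=C\c3ccc(OC)c(OC)c3)C2=O)cc1OC`) gives 6400 nM, and compound 2 (`COc1cc(/C=C2\CNC/C(=C\c3cc(OC)c(OC)c(OC)c3)C2=O)cc(OC)c1OC`) gives 1500 nM. Compound 2 thus holds the lower of the two numbers, and its gap to compound 1 is larger than the usual scatter between repeated measurements, so it is the stronger inhibitor of this pair.

The next compound, compound 3 (`COc1cc(/C=C2\CN(C)C/C(=C\c3cc(OC)c(OC)c(OC)c3)C2=O)cc(OC)c1OC`), differs from compound 2 in one place: methyl in place of hydrogen on an amine nitrogen in a ring, which means methyl in place of hydrogen on an amine nitrogen in a ring. Among the compounds with values here, no pair of measured compounds shows this change on its own, so the numbers so far give no direct guide to its size or direction. The expectation is therefore cautious: no step beyond the scatter is expected, and the estimated step of a 1.3-fold lower number from compound 2 to compound 3 (0.10 log units; within the scatter) reflects that. For compound 3, the estimated value in this assay is 1200 nM, with an expected range from 400 nM to 3500 nM.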

Compound 3, half-maximal inhibitory concentration: 1000 nM
For compound 3 the middle estimate is 1.2-fold (0.08 log units) above the measured one; the measured number falls inside the stated range.
By their numbers in this assay, from the lowest: compounds 3 and 2 (each within the scatter of the next); then compound 1.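

In this assay, within the data shown here, methyl in place of hydrogen on an amine nitrogen in a ring gives a 1.5-fold lower number from compound 2 to compound 3 (0.18 log units; within the scatter), which is the first view of this change on its own, and a step of this size cannot be told apart from the differences seen between repeated measurements. For this one pair, the hydrogen on that nitrogen therefore shows no sign of being needed for the cytotoxic effect, since compound 3 carries methyl there and its number stays level with that of compound 2. Nothing available explains this result at the level of cause, so the pair records only the outcome and not the reason for it.

Still open, as far as these compounds go, is whether this nitrogen would tolerate something bigger than methyl, such as a longer chain like propyl, a benzyl group or an acetyl group, or whether the number would then move clearly beyond the scatter. Also open, from the compounds shown here alone, is whether the same methyl swap would give a similar result on compound 1, whose aromatic rings carry a different set of methoxy groups.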